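Replacing the ethyl group of compound 1

The compounds below may be only part of what the source reports. "The series", "measured", "known", "first", "only" and "open" are said of these compounds alone.

Measured so far in a functional assay on HepG2 cells (Homo sapiens) for inhibition, read by MTT assay, with a stated time of 72 h; on this read-out lower numbers stand for stronger inhibition and higher numbers for weaker inhibition:
- compound 1 `CCc1ccc(NC(=O)C2CCN(C/C=C/c3ccccc3)CC2)cc1` gives 23300 nM
- compound 2 `O=C(Nc1cccc(Cl)c1)C1CCN(C/C=C/c2ccccc2)CC1` gives 20000 nM
- compound 3 `O=C(Nc1cccc(Br)c1)C1CCN(C/C=C/c2ccccc2)CC1` gives 19200 nM

Compound 1 stands level with the other two, since all three values lie within the usual scatter of one another. The next compound, compound 4 `CN1CCN(c2ccc(NC(=O)C3CCN(C/C=C/c4ccccc4)CC3)cc2)CC1`, differs from compound 1 in one place (4-methylpiperazin-1-yl in place of ethyl on an aromatic carbon): 4-methylpiperazin-1-yl in place of ethyl on an aromatic carbon.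

Three measured steps offer some guidance. Putting 3-chlorophenyl in place of 4-ethylphenyl on the amide-type nitrogen gives a 1.2-fold lower number from compound 1 to compound 2 (0.07 log units; within the scatter), and 3-bromophenyl in the same place gives a 1.2-fold lower number from compound 1 to compound 3 (0.08 log units; within the scatter). Bromo in place of chloro gives a 1.0-fold lower number from compound 2 to compound 3 (0.02 log units; within the scatter). Each of these steps is small, but none of them tests the new group. For the measured compounds named here, no measured compound carries 4-methylpiperazin-1-yl, so the data say nothing direct about it and any forecast needs a wide range.

The expectation therefore starts from compound 1 at 23300 nM and allows only a slight shift. The expected result is a 1.6-fold lower number from compound 1 to compound 4 (0.19 log units; within the scatter), with no change beyond the scatter in this assay. Compound 4 is estimated at 15000 nM (expected range 4000 nM to 40000 nM).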

Compound 4, half-maximal inhibitory concentration: 35200 nM
Estimate against measurement, compound 4: 2.3-fold (0.37 log units) below, and the stated range covers the measured number.
By their numbers in this assay, from the lowest: compounds 3, 2, 1 and 4 (each within the scatter of the next).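

In this assay, putting 4-methylpiperazin-1-yl in place of ethyl gives a 1.5-fold higher number from compound 1 to compound 4 (0.18 log units; within the scatter), so even this much larger group leaves the number level with that of the ethyl compound. The earlier compounds shown here varied only the substituted phenyl on the amide-type nitrogen, with small groups such as chloro and bromo, whereas this step shows that an aromatic carbon para to a large group can carry 7 heavy atoms instead of 2, including one six-membered non-aromatic ring with 2 hetero atoms and 2 hydrogen-bond acceptors, with no change beyond the scatter. Nothing available explains this tolerance, and the result itself gives no cause for it.

The compounds shown leave open whether any group at this place can move the number beyond the scatter, and a carboxylic acid, a plain amino group or a morpholine ring would each test that. Also open, going by these compounds, is whether a change elsewhere in the shared core, rather than on this aromatic ring, would do more in this cell assay than any of the swaps seen so far.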